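Nitro series: benzyloxy in place of phenyl

The source may report more compounds than this note shows. Statements on the series, on what has been measured and on what is new or still open speak of the compounds shown alone.

Measured so far:
compound 1 `Oc1nc2ccc(C(F)(F)F)cc2c(O)c1-c1ccccc1`
compound 2 `O=[N+]([O-])c1cc2c(O)c(-c3ccccc3)c(O)nc2cc1F`
compound 3 `O=[N+]([O-])c1cc2c(O)c(-c3ccc(-c4ccccc4)cc3)c(O)nc2cc1Cl`

In an assay on isolated protein for inhibition of fatty acid synthase (Rattus norvegicus) (a lower number here means a stronger inhibitor, a higher number a weaker inhibitor), compound 1 reaches only a limit, > 15000 nM (the limit of > 15000 nM in this assay, at which 1 of the 3 values shown sits). Compound 2 gives 50 nM in this assay. Compound 3 gives 122 nM and so stands at the highest of the two numbers; the nearest value, that of compound 2, lies at a lower number, a gap beyond the scatter.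

Compound 4 `O=[N+]([O-])c1cc2c(O)c(-c3ccc(OCc4ccccc4)cc3)c(O)nc2cc1Cl` differs from compound 3 by benzyloxy in place of phenyl on an aromatic carbon. For the measured compounds named here, no measured pair covers a change of this kind, so the step is expected to stay within the scatter, with a slight lean toward a higher number. Compound 4 is expected to give 160 nM, with a range from 55 nM to 480 nM. The expected step is a 1.3-fold higher number from compound 3 to compound 4 (0.12 log units; within the scatter).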

Compound 4, half-maximal inhibitory concentration: 86 nM
Estimate against measurement, compound 4: 1.9-fold (0.27 log units) above; the range from low to high includes it.
By their numbers in this assay, from the lowest: compounds 2, 4 and 3 (each within the scatter of the next, the first and the last beyond it). At a limit, above all of these: compound 1.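

In this assay, benzyloxy in place of phenyl gives a 1.4-fold lower number from compound 3 to compound 4 (0.15 log units; within the scatter) and so this position, para to a large group, accepts the larger group with its added hydrogen-bond acceptor without a change beyond the scatter. The result holds for this one pair only, in the chloro nitro series. Nothing measured here accounts for the step.

The compounds shown leave open whether an amine, a carboxylic acid or a longer chain in place of benzyloxy would be tolerated at this position.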